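The compounds below may be only part of what the source reports. "The series", "measured", "known", "first", "only" and "open" are said of these compounds alone.

Compound 3 `Nc1ncnc2c1c(-c1cnc3[nH]ccc3c1)nn2CCCCCCC(=O)NO` carries a hydroxamic acid on a chain attached to the shared core, and in a functional assay on HCT-116 cells (Homo sapiens) for inhibition, read by MTT assay, with a stated time of 72 h (a lower number here means a stronger inhibitor, a higher number a weaker inhibitor), compound 3 gives 9860 nM. Of the two numbers available, this is the lowest; compound 2 `Nc1nc2cc(-c3nn(CCCCCCCCCC(=O)NO)c4ncnc(N)c34)ccc2o1`, which bears a different aromatic group on the same core and a longer chain, gives 23100 nM in this assay, a higher number beyond the scatter. Compound 1 `Nc1ncnc2c1c(-c1cnc3[nH]ccc3c1)nn2CCCC(=O)NO` is the shorter-chain analogue of compound 3; in this assay compound 1 yields only a limit, > 150000 nM. Among the measured compounds shown here, the one step that can be read is an at least 15-fold lower number from compound 1 to compound 3 (1.18 log units; beyond the scatter), a large drop that accompanies lengthening of the chain. Compound 4 `Nc1ncnc2c1c(-c1cnc3[nH]ccc3c1)nn2CCCCCCCCCC(=O)NO` extends the chain of compound 3 once more: 3-(hydroxycarbamoyl)propyl in place of hydroxycarbamoyl on a saturated chain carbon, six bonds along the chain from an aromatic nitrogen. For the measured compounds named here, that step bears on the single measured one, yet the only compound already carrying a chain of this length, compound 2, gives a number above that of compound 3, so a further large gain is not assumed. The expected step is a 1.6-fold lower number from compound 3 to compound 4 (0.22 log units; within the scatter), lying within or close to the scatter. Compound 4 is therefore estimated at 6000 nM in this assay, with a range from 1500 nM to 25000 nM.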

Compound 4, half-maximal inhibitory concentration: 18700 nM
Estimate against measurement, compound 4: 3.1-fold (0.49 log units) below; measured number inside the range.
By their numbers in this assay, from the lowest: compounds 3, 4 and 2 (each within the scatter of the next, the first and the last beyond it). At a limit, above all of these: compound 1.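

Putting 3-(hydroxycarbamoyl)propyl in place of hydroxycarbamoyl, on a saturated chain carbon six bonds along the chain from an aromatic nitrogen, gives a 1.9-fold higher number from compound 3 to compound 4 (0.28 log units; within the scatter) in this assay, so the large step seen three bonds along the chain is not repeated at this position. At this chain length, the two aromatic groups cannot be told apart in this assay, with a 1.2-fold lower number from compound 2 to compound 4 (0.09 log units; within the scatter), so the earlier gap beyond the scatter between compound 2 and compound 3 now appears alongside a chain change and not as a clear effect of the aromatic group alone. Taken over the whole chain extension, the record shows an at least 8.0-fold lower number from compound 1 to compound 4 (0.90 log units; beyond the scatter), a step still beyond the scatter whose starting point is a limit and not a number: the limit of > 150000 nM in this assay, at which 1 of the 4 values shown sits.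

From the compounds shown here alone, how a carboxylic acid or an amine at the end of the chain would compare with hydroxycarbamoyl stays open. So does the effect of a chain longer than that of compound 4, and of a chain of a length lying in the gap left by compound 3 and compound 4.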